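The source may hold more compounds than are shown below. What is called first, only, known or untested is meant among the compounds shown, and "the series" means these compounds.

Among the measured compounds shown here, compound 3, `CCCNc1cc(Oc2ccc(NC(=O)Nc3cccc(C(F)(F)F)c3)cc2)ncn1`, gives 32 nM in an assay on isolated protein for inhibition of serine/threonine-protein kinase TNNI3K (Homo sapiens) (on this read-out lower numbers stand for stronger inhibition and higher numbers for weaker inhibition), the second highest of the three numbers measured so far. Its closest neighbour is compound 1, `CCNc1cc(Oc2ccc(NC(=O)Nc3cccc(C(F)(F)F)c3)cc2)ncn1`, which gives 25 nM; the step of a 1.3-fold higher number from compound 1 to compound 3 (0.11 log units; within the scatter) is within the scatter. The furthest is compound 2, `COc1cc(Oc2ccc(NC(=O)Nc3cccc(C(F)(F)F)c3)cc2)ncn1`, which gives 4000 nM; the step of a 130-fold lower number from compound 2 to compound 3 (2.10 log units; beyond the scatter) is large.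

Compound 4, `CN(C)c1cc(Oc2ccc(NC(=O)Nc3cccc(C(F)(F)F)c3)cc2)ncn1`, differs from compound 3 in one place: dimethylamino in place of propylamino on an aromatic carbon. For the measured compounds named here, two measured steps bear on this. The lengthening of the alkyl chain, a 1.3-fold higher number from compound 1 to compound 3 (0.11 log units; within the scatter), changed nothing beyond the scatter, so the loss of one carbon on its own carries little weight. The replacement of the amino group that carries a hydrogen-bond donor by a group with none, a 160-fold higher number from compound 1 to compound 2 (2.20 log units; beyond the scatter), was large. Compound 4 keeps the nitrogen but loses the donor, a case between the two, so a weakening of moderate size is expected: a 7.8-fold higher number from compound 3 to compound 4 (0.89 log units; beyond the scatter). Compound 4 is therefore estimated at 250 nM, within a range from 40 nM to 2000 nM.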

Compound 4, half-maximal inhibitory concentration: 2500 nM
Beside the measured number, compound 4's estimate is 10-fold (1.00 log units) below it; the measured number lies above the stated range.
By their numbers in this assay, from the lowest: compounds 1 and 3 (each within the scatter of the next); then compounds 4 and 2 (each within the scatter of the next).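

In this assay the nitrogen at this position does not by itself hold the low number: dimethylamino in place of propylamino is a large step (a 78-fold higher number from compound 3 to compound 4 (1.89 log units; beyond the scatter)), as is dimethylamino in place of ethylamino (a 100-fold higher number from compound 1 to compound 4 (2.00 log units; beyond the scatter)), whereas dimethylamino and methoxy do not separate (a 1.6-fold lower number from compound 2 to compound 4 (0.20 log units; within the scatter)). Across these four compounds, ethylamino and propylamino, each on the same aromatic carbon, stand together far from dimethylamino and methoxy, and no compound shown goes against that split. Nothing measured here explains the change.

Since dimethylamino differs from propylamino in both its chain and its nitrogen hydrogen, the compounds shown do not separate those two differences. Methylamino, with a single methyl on the nitrogen, or N-methyl-N-ethylamino would help to place the step, and whether a cyclic amine such as pyrrolidine follows dimethylamino also remains open.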